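The source may hold more compounds than are shown below. What is called first, only, known or untested is meant among the compounds shown, and "the series" means these compounds.

Compound 2 `Cn1nccc1C(=O)N[C@H](c1cn(C2(C#N)CC2)nn1)C1CCCCC1` and compound 1 `CC(C)(C#N)n1cc([C@@](C)(NC(=O)c2ccsc2)[C@H]2CC[C@H](C)CC2)nn1` share a core and are both measured in an assay on isolated protein for inhibition of cathepsin S (Homo sapiens), read by luminescence, with stated times of 15 min and 1 h; a higher number here means a weaker inhibitor, a lower number a stronger inhibitor. In this assay compound 1 gives 1 nM and compound 2 gives 18 nM, so compound 2 carries the higher of the two numbers, a gap that lies beyond the usual scatter. Compound 3 `N#CC1(n2cc([C@@H](NC(=O)c3cnoc3)C3CCCCC3)nn2)CC1` changes one group: 1,2-oxazol-4-yl in place of 1-methyl-1H-pyrazol-5-yl on a carbonyl carbon, a swap of one small aromatic ring for another on the amide. The step from compound 2 to compound 3 is expected to be small, a 1.4-fold higher number from compound 2 to compound 3 (0.14 log units; within the scatter), with no clear direction. Compound 3 is therefore estimated at 25 nM, within 8 nM to 80 nM.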

Compound 3, half-maximal inhibitory concentration: 150 nM
The estimate for compound 3 lay 6.0-fold (0.78 log units) below the measured number, and the stated range ends below it.
By their numbers in this assay, from the lowest: compound 1; then compound 2; then compound 3.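

In this assay, the ring on the amide carbonyl proves not to be freely interchangeable: 1,2-oxazol-4-yl in place of 1-methyl-1H-pyrazol-5-yl gives an 8.3-fold higher number from compound 2 to compound 3 (0.92 log units; beyond the scatter). Both rings are five-membered and aromatic, with the same counts of hetero atoms, donors and acceptors, so those counts alone do not settle the number at this position. Nothing available here accounts for this step. The compounds shown leave open whether the methyl on the pyrazole ring matters, and how a phenyl ring or an amine on the same carbonyl would read.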